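Hydroxy to fluoro on a central chain carbon: expected antiproliferative outcome

The source may hold more compounds than are shown below. What is called first, only, known or untested is meant among the compounds shown, and "the series" means these compounds.

Measured compounds:
compound 1 `COc1nc(CC(O)(COC(C)=O)COC(C)=O)c(C)c(OC)n1` – > 100000 nM
compound 2 `Cc1c(CC(O)(CO)CO)n(C)c(=O)[nH]c1=O` – > 100000 nM
compound 3 `CC(=O)OCC(O)(COC(C)=O)Cc1c(C)c(=O)[nH]c(=O)n1C` – > 100000 nM

In an ADME assay on WI-38 cells (Homo sapiens) for antiproliferative activity, read by MTT assay, with a stated time of 72 h (on this read-out higher numbers stand for weaker inhibition and lower numbers for stronger inhibition), compound 1 reaches only a limit of the assay, > 100000 nM. Compound 2 likewise reaches only a limit in this assay, > 100000 nM. Compound 3 also gives only a limit in this assay, > 100000 nM, so no number is known for it. Where compound 3 stands is therefore fixed by the range of this assay rather than by its own potency: all three measured compounds sit at the same ceiling, as noted in the limit of > 100000 nM in this assay, at which 3 of the 3 values shown sit, and no ordering among them can be read from the data.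

Compound 4 `CC(=O)OCC(F)(COC(C)=O)Cc1c(C)c(=O)[nH]c(=O)n1C` differs from compound 3 in one spot: fluoro in place of hydroxy on a saturated chain carbon bound to three saturated chain carbons. For the measured compounds named here, no pair of measured compounds shows the effect of such a change, so the step can only be anticipated. Since every measured compound already sits at the limit, the step from compound 3 to compound 4 is expected to be none beyond the scatter, as a step that the limit leaves unreadable from compound 3 to compound 4 expresses. For compound 4 in this assay the expected value is 150000 nM, within 50000 nM to 500000 nM, most likely again reported as a limit.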

Compound 4, half-maximal inhibitory concentration: > 100000 nM
Compound 4: only a limit was reported; the forecaster's own chance of this, stated with the estimate: 85%; the middle value lies beyond the limit too.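

No step from compound 3 to compound 4 can be read in this assay, because both results are limits and not numbers, as for every compound shown: the limit of > 100000 nM in this assay, at which 4 of the 4 values shown sit.

The compounds shown leave open whether fluoro in place of hydroxy changes the antiproliferative activity at all, and how far any of the four compounds lies beyond that limit.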